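A few compounds are considered here, and "the series" means these few. Any claim that something is new, unique, unknown or untested is made for them only; others in the source may bear on it.

Compound 1 `Cc1cc(Nc2cc(Cl)cc(S(F)(F)(F)(F)F)c2)nc(N)n1` in an assay on cells for inhibition of S-adenosylmethionine decarboxylase proenzyme (Homo sapiens), read by mass spectrometry, at pH 7.2 (a lower number here means a stronger inhibitor, a higher number a weaker inhibitor), gives > 180000 nM, a limit of the assay rather than a number. Compound 2 `Cc1cc(Nc2cccc(Cl)c2)nc(N)n1` in this assay gives > 180000 nM, again a limit and not a number. Compound 3 `Cc1cc(Nc2cccc(Br)c2)nc(N)n1` in this assay gives > 180000 nM, likewise a limit.

Compound 2 therefore stands nowhere on a scale of numbers: its value is a limit, and the two other values shown are limits as well, all three sitting at the limit of > 180000 nM in this assay, at which 3 of the 3 values shown sit. The step that the two limits leave unreadable from compound 1 to compound 2 and the step that the two limits leave unreadable from compound 2 to compound 3 are both unreadable, since neither end of either step is a number.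

Compound 4 `Cc1cc(Nc2cc(Cl)ccc2Cl)nc(N)n1` differs from compound 2 by chloro in place of hydrogen on an aromatic carbon. Both measured steps bear on this change only in that neither of them produced a readable value, so no direction and no size can be drawn from them. The step from compound 2 to compound 4 in this assay is accordingly expected to be a step that the limit leaves unreadable from compound 2 to compound 4, with a result at the limit once more being the most probable outcome. Compound 4 is estimated at 200000 nM, within a range from 50000 nM to 1000000 nM.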

Compound 4, half-maximal inhibitory concentration: > 180000 nM
Compound 4 was reported as a limit; the forecaster's own chance of this, stated with the estimate: 80%; the middle value lies beyond the limit too.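

Compound 4, like compound 2, gives a limit and not a number, so no step can be read between compound 2 and compound 4: the limit of > 180000 nM in this assay, at which 4 of the 4 values shown sit. The compounds shown leave open whether any change on the shared core would give a readable value in this assay.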